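Lengthening the phenyl-bearing chain: compound 2 to compound 3

The source may hold more compounds than are shown below. What is called first, only, known or untested is meant among the compounds shown, and "the series" means these compounds.

Measured compounds:
compound 1 `CCC(CC)(c1ccc(OCC(=O)C(C)(C)Cc2ccccc2)c(C)c1)c1ccc(OC[C@@H](O)CO)c(C)c1`, in an assay on HL-60 cells for activation of vitamin D3 receptor (Homo sapiens) (a higher number here means that more compound is needed for the effect, a lower number that less compound is needed), compound 1 gives 21000 nM
compound 2 `CCC(CC)(c1ccc(OCC(=O)C(C)(C)CCc2ccccc2)c(C)c1)c1ccc(OC[C@@H](O)CO)c(C)c1`, in this assay compound 2 gives 23000 nM

Compound 2 holds the higher of the two numbers in this assay, yet its nearest neighbour, compound 1, sits within the scatter: a 1.1-fold higher number from compound 1 to compound 2 (0.04 log units; within the scatter). Compound 3 `CCC(CC)(c1ccc(OCC(=O)C(C)(C)CCCc2ccccc2)c(C)c1)c1ccc(OC[C@@H](O)CO)c(C)c1` differs from compound 2 by benzyl in place of phenyl on a saturated chain carbon, three bonds along the chain from a carbonyl carbon. Going by the values given here, the only measured step that bears on this change, a 1.1-fold higher number from compound 1 to compound 2 (0.04 log units; within the scatter), was within the scatter, so no step beyond the scatter is expected in this assay in either direction. Compound 3 is therefore estimated at 23000 nM, with a range from 9000 nM to 55000 nM, an expected step of no change at the digits printed from compound 2 to compound 3 (within the scatter).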

Compound 3, half-maximal effective concentration: > 30000 nM
Compound 3 ended at the assay's limit; the forecaster's own chance of this, stated with the estimate: 10%; middle value at least 1.3-fold (0.11 log units) away from the limit.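

In this assay compound 3 gives > 30000 nM, which is a limit of the assay and not a number. The added chain carbon can therefore be read only as a floor: an at least 1.3-fold higher number from compound 2 to compound 3 (0.11 log units; that floor lies within the scatter), and likewise an at least 1.4-fold higher number from compound 1 to compound 3 (0.15 log units; that floor lies within the scatter). Across these compounds, the 1,1-dimethyl-4-phenylbutyl chain brings no lower number at this position, unlike what a shorter chain might have suggested only if the trend had reversed.

On these data alone, whether compound 3 truly lies beyond the scatter of compound 2 remains open. So does the effect of an amine or a carboxylic acid in place of the phenyl on this chain.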